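Trimming a Methyl from the Aniline Nitrogen

The source may report more compounds than this note shows. Statements on the series, on what has been measured and on what is new or still open speak of the compounds shown alone.

Of the compounds shown here, two have so far been measured in a physicochemical assay for lipophilicity, read by HPLC, at pH 7.5; on this read-out higher numbers stand for higher lipophilicity and lower numbers for lower lipophilicity. Compound 1 `CCOc1ccccc1-c1ccc(-c2nc3cnccc3cc2C#N)cc1` gives 3.8. Compound 2 `CC[C@@H](Nc1c(C#N)c(-c2ccc(-c3ccccc3N(C)C)cc2)nc2cnccc12)C(N)=O` gives 3.2, the lower of the two numbers, and the gap to compound 1, which stands higher, is wider than the usual scatter of such measurements. Among the measured compounds shown here, the two structures differ in several places at once, so no single step between them can be read off.

Compound 3 `CC[C@@H](Nc1c(C#N)c(-c2ccc(-c3ccccc3NC)cc2)nc2cnccc12)C(N)=O` has not yet been measured. It differs from compound 2 in one place only (hydrogen in place of methyl on a nitrogen on an aromatic ring), the change that turns 2-(dimethylamino)phenyl into 2-(methylamino)phenyl.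

For the measured compounds named here, with no measured pair to lean on, the size of the step has to be estimated from the change alone. The step from compound 2 to compound 3 is expected to be a number 0.40 log units lower from compound 2 to compound 3 (beyond the scatter), a modest fall in this assay, small enough that a single repeat could place it within the scatter. Compound 3 is therefore expected to give about 2.8, most likely between 2.4 and 3.2.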

Compound 3, distribution coefficient: 2.5
Compound 3: the middle estimate sits 0.30 log units above what was measured; low and high end bracket the measured number.
By their numbers in this assay, from the lowest: compound 3; then compound 2; then compound 1.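

Among the compounds shown here, this is the first step that can be read on its own: with the rest of the structure unchanged, hydrogen in place of methyl on a nitrogen on an aromatic ring gives a number 0.70 log units lower from compound 2 to compound 3 (beyond the scatter) in this assay. The gap between the two earlier compounds spread over several places at once and could be tied to no single group, whereas here the change from dimethylamino to methylamino carries the whole difference. One carbon at this position is thus enough to move the read-out by more than repeat measurements would scatter. No measurement shown explains why the number moves this far.

On these data alone, it remains open whether a second hydrogen on the same nitrogen, giving a primary amine, would bring a further fall of similar size, and whether an ethyl in place of the remaining methyl would reverse the direction. Also open, as far as these compounds go, is whether the same swap from dimethylamino to methylamino gives a similar step on a different core, since a single pair cannot establish a general pattern.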